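Opening the ring: cyclopentyl to isobutyl on the ether

The source may hold more compounds than are shown below. What is called first, only, known or untested is meant among the compounds shown, and "the series" means these compounds.

Measured compounds:
- compound 1, `O=C(/C=C/c1ccc(O)cc1)c1c(O)cccc1OCC1CCCCC1`: > 30000 nM
- compound 2, `O=C(/C=C/c1ccc(O)cc1)c1c(O)cccc1OCCC1CCCC1`: 3310 nM
- compound 3, `O=C(/C=C/c1ccc(O)cc1)c1c(O)cccc1OCC1CCCC1`: 3410 nM

In a functional assay on HCT-15 cells (Homo sapiens) for antiproliferative activity, read by sulforhodamine B assay (on this read-out lower numbers stand for stronger inhibition of growth and higher numbers for weaker inhibition of growth), compound 3 gives 3410 nM. Compound 2 gives 3310 nM, and the two values sit within the scatter, as a 1.0-fold higher number from compound 2 to compound 3 (0.01 log units; within the scatter) shows. For compound 1 the assay returns only a limit, (the limit of > 30000 nM in this assay, at which 1 of the 3 values shown sits), so no number is known for it. Among the two numbers given, compound 3 stands highest, with compound 2 nearest.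

Compound 4 is `CC(C)CCOc1cccc(O)c1C(=O)/C=C/c1ccc(O)cc1`. It differs from compound 3 in one place: isobutyl in place of cyclopentyl on a saturated chain carbon bound to an oxygen on an aromatic ring.

Among the compounds with values here, no measured step covers an opening of the ring, so the closest guidance is indirect. The steps of an at least 9.0-fold lower number from compound 1 to compound 2 (0.95 log units; beyond the scatter) and an at least 8.7-fold lower number from compound 1 to compound 3 (0.94 log units; beyond the scatter) show that the two five-membered groups give numbers where the cyclohexyl gives a limit, while a 1.0-fold higher number from compound 2 to compound 3 (0.01 log units; within the scatter) shows that one more chain carbon between ring and oxygen changes nothing beyond the scatter. Isobutyl is of similar size to these five-membered groups, so the expected step of a 1.2-fold higher number from compound 3 to compound 4 (0.07 log units; within the scatter) is small and within the scatter, in no firm direction. Compound 4 is therefore expected to give about 4000 nM, estimated between 1500 nM and 12000 nM.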

Compound 4, concentration for 50% growth inhibition: 10600 nM
For compound 4 the middle estimate is 2.7-fold (0.42 log units) below the measured one; the measured number falls inside the stated range.
By their numbers in this assay, from the lowest: compounds 2 and 3 (each within the scatter of the next); then compound 4. At a limit, above all of these: compound 1.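

In this assay, the open isopentyl chain gives a higher number than either ring-bearing ether, a change that earlier steps did not show, as both a 3.1-fold higher number from compound 3 to compound 4 (0.49 log units; beyond the scatter) and a 3.2-fold higher number from compound 2 to compound 4 (0.51 log units; beyond the scatter) lie beyond the scatter, so at this place on a saturated chain carbon bound to an oxygen on an aromatic ring, the cyclopentyl ring cannot be swapped for isobutyl without a measurable loss of growth inhibition. Compound 1 stands at a limit and has no number: the limit of > 30000 nM in this assay, at which 1 of the 4 values shown sits. Its step can be read only as a bound, an at least 2.8-fold lower number from compound 1 to compound 4 (0.45 log units; beyond the scatter), so the open chain still gives a lower number than the cyclohexyl group, and the position is sensitive to more than ring size alone, with the two five-membered ring groups giving the lowest numbers of the four.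

The compounds shown leave open how a straight pentyl chain or a smaller ring such as cyclobutyl would read at this position. They also leave open whether an amine or a hydroxyl group carried on the cyclopentyl ring would keep the number of compound 3.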